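Fluoro for methyl on the 2-methylbenzyl series

The source may hold more compounds than are shown below. What is called first, only, known or untested is meant among the compounds shown, and "the series" means these compounds.

Measured in a functional assay on HepG2 cells (Homo sapiens) for antiproliferative activity, read by MTT assay, with a stated time of 24 h; a higher number here means a weaker inhibitor, a lower number a stronger inhibitor:
- compound 1 `O=[N+]([O-])c1ccc(CSc2nnc(-c3ccc4c(c3)OCCO4)n2-c2ccccc2)cc1`: 13800 nM
- compound 2 `Clc1cccc(CSc2nnc(-c3ccc4c(c3)OCCO4)n2-c2ccccc2)c1`: 2390 nM
- compound 3 `Cc1ccccc1CSc1nnc(-c2ccc3c(c2)OCCO3)n1-c1ccccc1`: 20500 nM

Compound 3 gives 20500 nM and shares the weak end of this small set with compound 1, as shown by a 1.5-fold higher number from compound 1 to compound 3 (0.17 log units; within the scatter). Compound 2 stands apart, with an 8.6-fold higher number from compound 2 to compound 3 (0.93 log units; beyond the scatter).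

The next compound is compound 4 `Fc1ccccc1CSc1nnc(-c2ccc3c(c2)OCCO3)n1-c1ccccc1`, not yet measured. It carries fluoro in place of methyl on an aromatic carbon, ortho to a large group, so that 2-methylbenzyl becomes 2-fluorobenzyl: fluoro in place of methyl on an aromatic carbon.

Among the compounds with values here, no measured step makes this exact exchange. The nearest evidence comes from changes to the substituted phenyl on the saturated chain carbon bound to a sulfur. These run from a 1.5-fold higher number from compound 1 to compound 3 (0.17 log units; within the scatter) to the modest 5.8-fold lower number from compound 1 to compound 2 (0.76 log units; beyond the scatter) and an 8.6-fold higher number from compound 2 to compound 3 (0.93 log units; beyond the scatter), and the larger two both involve the 3-chlorophenyl of compound 2. This small exchange is therefore not expected to give a step beyond the scatter in this assay, with any drift towards a lower number, as compound 3 already has a high value at 20500 nM.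

The expected step is a 1.7-fold lower number from compound 3 to compound 4 (0.23 log units; within the scatter). For compound 4 the estimate is 12000 nM, with an expected range of 4000 nM to 30000 nM.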

Compound 4, half-maximal inhibitory concentration: 810 nM
Compound 4: middle estimate off by 15-fold (1.17 log units), on the high side; measured number outside the range, below it.
By their numbers in this assay, from the lowest: compound 4; then compound 2; then compounds 1 and 3 (each within the scatter of the next).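

In this assay, within the data shown here, fluoro in place of methyl on an aromatic carbon, ortho to a large group, gives a 25-fold lower number from compound 3 to compound 4 (1.40 log units; beyond the scatter), a larger step than any among the earlier compounds, the biggest of which was an 8.6-fold higher number from compound 2 to compound 3 (0.93 log units; beyond the scatter). This position on the benzyl group is therefore far more sensitive to the identity of the substituent than compounds 1, 2 and 3 could show, and the 3-chlorophenyl of compound 2 no longer marks the low end of the series: the change to 2-fluorobenzyl gives a 3.0-fold lower number from compound 2 to compound 4 (0.47 log units; beyond the scatter), while the change from the 4-nitrophenyl gives a 17-fold lower number from compound 1 to compound 4 (1.23 log units; beyond the scatter), leaving compound 4 as the strongest of the four. No measured evidence accounts for the size of this step.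

As far as these compounds go, without plain benzyl, it remains open whether fluoro lowers the number or methyl raises it relative to an unsubstituted ring. It is equally unclear whether 2-chlorobenzyl or 2-methoxybenzyl would follow compound 4 or compound 3, or whether 3-fluorobenzyl and 4-fluorobenzyl would keep the low value with fluoro elsewhere on the ring.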